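Swapping the sulfur-linked group on a shared core

The compounds below may be only part of what the source reports. "The series", "measured", "known", "first", "only" and "open" are said of these compounds alone.

Three compounds share one core and differ only in the group attached to a sulfur. Compound 1 `CC(C)c1n[nH]c2c(NCc3ccc(-c4ccccn4)cc3)nc(SCC3CNC(=O)O3)nc12` carries a (2-oxo-1,3-oxazolidin-5-yl)methyl there; in a functional assay on HT cells (Homo sapiens) for antiproliferative activity, read by fluorescence, with a stated time of 72 h (on this read-out higher numbers stand for weaker inhibition of growth and lower numbers for stronger inhibition of growth), compound 1 gives 80 nM, the lowest of the three numbers, though each of the others lies within the usual scatter of it. Compound 2 `CC(C)c1n[nH]c2c(NCc3ccc(-c4ccccn4)cc3)nc(SCCn3ccnc3)nc12` gives 155 nM and compound 3 `CC(C)c1n[nH]c2c(NCc3ccc(-c4ccccn4)cc3)nc(SCCCO)nc12` gives 109 nM. The two measured steps from compound 1, a 1.9-fold higher number from compound 1 to compound 2 (0.29 log units; within the scatter) and a 1.4-fold higher number from compound 1 to compound 3 (0.13 log units; within the scatter), both stay within the scatter, as does a 1.4-fold lower number from compound 2 to compound 3 (0.15 log units; within the scatter).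

Compound 4 `CC(C)c1n[nH]c2c(NCc3ccc(-c4ccccn4)cc3)nc(SC3CCCCC3N)nc12` is the next step from compound 1: 2-aminocyclohexyl in place of (2-oxo-1,3-oxazolidin-5-yl)methyl on a sulfur. The new group keeps a ring and a hydrogen-bond donor but is carbon only apart from one nitrogen.

Both measured steps from compound 1 bear on this change, since each also replaced the group on the sulfur, and neither moved the number beyond the scatter. On that basis compound 4 is expected to give a number close to compound 1, with no step beyond the scatter in either direction, so the expected step is a 1.3-fold higher number from compound 1 to compound 4 (0.10 log units; within the scatter). The estimate for compound 4 in this assay is 100 nM, expected to fall between 40 nM and 250 nM.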

Compound 4, concentration for 50% growth inhibition: 139 nM
Beside the measured number, compound 4's estimate is 1.4-fold (0.14 log units) below it; the range from low to high includes it.
By their numbers in this assay, from the lowest: compounds 1, 3, 4 and 2 (each within the scatter of the next).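

In this assay the group on the sulfur can be a six-membered ring of carbon only, the 2-aminocyclohexyl of compound 4, and the number stays within the scatter of all three earlier compounds. Against the (2-oxo-1,3-oxazolidin-5-yl)methyl the change gives (a 1.7-fold higher number from compound 1 to compound 4 (0.24 log units; within the scatter)), against the 3-hydroxypropyl it gives (a 1.3-fold higher number from compound 3 to compound 4 (0.11 log units; within the scatter)), and against the 2-(1H-imidazol-1-yl)ethyl it gives (a 1.1-fold lower number from compound 2 to compound 4 (0.05 log units; within the scatter)), so these four quite different groups cannot be told apart on this read-out. Nothing at hand explains why such different groups read so alike.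

All four compounds lie within the scatter of one another, which leaves open whether any group on this sulfur can move the number beyond it in either direction. A plain cyclohexyl, which would show what the amine on the ring of compound 4 contributes, or a carboxylic acid at the end of a longer chain, would be the kind of group to test that.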